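Shifting a Methoxy Group: Compound 1 to Compound 4

The source may report more compounds than this note shows. Statements on the series, on what has been measured and on what is new or still open speak of the compounds shown alone.

Three compounds sharing one core were tested in an ADME assay on cells (Macrophage) for cytotoxicity, read by MTT assay, with a stated time of 24 h; a lower number here means that less compound is tolerated, a higher number that more compound is tolerated. Compound 1 `COc1ccc(/C=C/C(=O)NNC(=O)c2ccc3c(c2)OCCO3)cc1` gives 319000 nM, the second highest of the three numbers. Compound 2 `Cc1ccccc1/C=C/C(=O)NNC(=O)c1ccc2c(c1)OCCO2` gives 268000 nM and compound 3 `O=C(/C=C/c1cccc(Br)c1)NNC(=O)c1ccc2c(c1)OCCO2` gives 351000 nM. The steps of a 1.2-fold lower number from compound 1 to compound 2 (0.08 log units; within the scatter), a 1.1-fold higher number from compound 1 to compound 3 (0.04 log units; within the scatter) and a 1.3-fold higher number from compound 2 to compound 3 (0.12 log units; within the scatter) all lie within the scatter. Compound 4 `COc1ccccc1/C=C/C(=O)NNC(=O)c1ccc2c(c1)OCCO2` differs from compound 1 by 2-methoxyphenyl in place of 4-methoxyphenyl on a double-bonded chain carbon bound to a double-bonded chain carbon. Going by the values given here, no measured step moves a methoxy group, but the three aryl exchanges, each within the scatter, suggest that changing the aryl substituent alters little here. Compound 4 is therefore expected to show no step beyond the scatter, a 1.0-fold lower number from compound 1 to compound 4 (0.01 log units; within the scatter). The estimated value of compound 4 is 310000 nM, with a range from 200000 nM to 480000 nM.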

Compound 4, half-maximal cytotoxic concentration: 312000 nM
For compound 4 the middle estimate is 1.0-fold (0.00 log units) below the measured one; measured number inside the range.
By their numbers in this assay, from the lowest: compounds 2, 4, 1 and 3 (each within the scatter of the next).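

Going by these compounds alone, the methoxy shift, a change the earlier compounds did not include, stays within the scatter in this assay (a 1.0-fold lower number from compound 1 to compound 4 (0.01 log units; within the scatter)), so 2-methoxyphenyl and 4-methoxyphenyl cannot be told apart at this place. The two further exchanges, methoxy in place of methyl on an aromatic carbon (a 1.2-fold higher number from compound 2 to compound 4 (0.07 log units; within the scatter)) and 2-methoxyphenyl in place of 3-bromophenyl (a 1.1-fold lower number from compound 3 to compound 4 (0.05 log units; within the scatter)), also stay within it. No evidence is at hand to explain these results.

The compounds shown leave open whether an amine or a carboxylic acid on the phenyl group would also stay within the scatter. They also leave open whether any change to the shared core would do so.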